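From 4-fluorophenyl to cyclohexyl: an expected half-life

The source may hold more compounds than are shown below. What is called first, only, known or untested is meant among the compounds shown, and "the series" means these compounds.

In an ADME assay on microsomes from liver (Homo sapiens) for metabolic stability (on this read-out higher numbers stand for a longer-lived compound and lower numbers for a shorter-lived compound), compound 1 `Cc1cccc(NC(=O)c2nn(C)c(-c3ccccc3)c2C)n1` gives 1.1 h and compound 2 `Cc1cccc(NC(=O)c2nn(C)c(-c3ccc(F)cc3)c2C)n1` gives 1.37 h, two values within the scatter of each other. Compound 3 `Cc1cccc(NC(=O)c2nn(C)c(-c3ccc(C(F)(F)F)cc3)c2C)n1` gives > 5 h, which is a limit of the assay and not a number.

Compound 4 `Cc1cccc(NC(=O)c2nn(C)c(C3CCCCC3)c2C)n1` differs from compound 2 in one place, where cyclohexyl stands in place of 4-fluorophenyl on an aromatic carbon: cyclohexyl in place of 4-fluorophenyl on an aromatic carbon.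

Trifluoromethyl brought the only measured steps beyond the scatter, an at least 4.5-fold higher number from compound 1 to compound 3 (0.65 log units; beyond the scatter) and an at least 3.6-fold higher number from compound 2 to compound 3 (0.56 log units; beyond the scatter). Fluoro in place of hydrogen brought a 1.2-fold higher number from compound 1 to compound 2 (0.10 log units; within the scatter), which lies within the scatter. None of these steps removes an aromatic ring, so they offer only loose guidance. Compound 4 carries no trifluoromethyl, so no gain is expected in this assay, and a small fall seems likelier.

The expected change is a 1.7-fold lower number from compound 2 to compound 4 (0.23 log units; within the scatter). The estimated half-life of compound 4 is 0.8 h, with an expected range from 0.3 h to 1.8 h.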

Compound 4, half-life: 1.38 h
Beside the measured number, compound 4's estimate is 1.7-fold (0.24 log units) below it; the range from low to high includes it.
By their numbers in this assay, from the lowest: compounds 1, 2 and 4 (each within the scatter of the next). At a limit, above all of these: compound 3.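

The earlier steps shown here changed only a group on the phenyl ring, whereas this one replaces the whole aromatic ring with a non-aromatic ring of carbon only. In this assay that replacement gives a 1.0-fold higher number from compound 2 to compound 4 (0.00 log units; within the scatter) and, starting from plain phenyl, a 1.3-fold higher number from compound 1 to compound 4 (0.10 log units; within the scatter) as well. Among these compounds, then, an aromatic ring at this place on the shared core is not needed to keep the half-life, and trifluoromethyl still brings the only steps beyond the scatter, though nothing measured here explains why the half-life holds across this replacement.

Still open, on these data alone, is whether trifluoromethyl on the cyclohexyl ring would bring a step like the one it brought on phenyl. Also open, as far as these compounds go, is how the half-life would read with an amine, a carboxylic acid or a longer chain at this place.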